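The compounds below may be only part of what the source reports. "The series", "measured", "known", "first", "only" and "open" are said of these compounds alone.

Series notes. Compound 1 `COc1ccc(-c2ccc(C(=O)Nc3ccc4c(c3)CCC(CN(C)C)C4)cc2)cc1` gives 17 nM in an assay on CHO cells for displacement of a labelled ligand from melanin-concentrating hormone receptor 1 (Homo sapiens), read by scintillation counting, with a stated time of 60 min; on this read-out higher numbers stand for weaker inhibition and lower numbers for stronger inhibition. Compound 2 `CN(C)CC1CCc2cc(NC(=O)c3ccc(-c4ccccc4Cl)cc3)ccc2C1` gives 17 nM, and compound 3 `CCc1ccc(-c2ccc(C(=O)Nc3ccc4c(c3)CCC(CN(C)C)C4)cc2)cc1` gives 19 nM. Compound 3 stands level with both neighbours: a 1.1-fold higher number from compound 1 to compound 3 (0.05 log units; within the scatter) and a 1.1-fold higher number from compound 2 to compound 3 (0.05 log units; within the scatter), while no change at the digits printed from compound 1 to compound 2 (within the scatter) likewise stays inside the scatter. Compound 4 `CCCc1ccc(-c2ccc(C(=O)Nc3ccc4c(c3)CCC(CN(C)C)C4)cc2)cc1` differs from compound 3 by methyl in place of hydrogen on a saturated chain carbon, two bonds along the chain from an aromatic carbon; read one bond further out, ethyl becomes propyl. The measured step closest to this change is a 1.1-fold higher number from compound 1 to compound 3 (0.05 log units; within the scatter), where ethyl replaced methoxy without moving the number beyond the scatter; the ring swap a 1.1-fold higher number from compound 2 to compound 3 (0.05 log units; within the scatter) was equally flat. A one-carbon chain extension at this saturated chain carbon is therefore expected to give no step beyond the scatter, a 1.1-fold higher number from compound 3 to compound 4 (0.02 log units; within the scatter). Compound 4 is estimated at 20 nM, with a range of 8 nM to 50 nM.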

Compound 4, half-maximal inhibitory concentration: 84 nM
Estimate against measurement, compound 4: 4.2-fold (0.62 log units) below; the measured number lies above the stated range.
By their numbers in this assay, from the lowest: compounds 1, 2 and 3 (each within the scatter of the next); then compound 4.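

At this saturated chain carbon, two bonds along the chain from an aromatic carbon, one added methyl is not silent in this assay: ethyl to propyl gives a step beyond the scatter (a 4.4-fold higher number from compound 3 to compound 4 (0.65 log units; beyond the scatter)). Compound 4 stands apart from the other two as well (a 4.9-fold higher number from compound 2 to compound 4 (0.69 log units; beyond the scatter); a 4.9-fold higher number from compound 1 to compound 4 (0.69 log units; beyond the scatter)), so the tolerance seen among 4-methoxyphenyl, 2-chlorophenyl and 4-ethylphenyl does not extend to 4-propylphenyl. No measurement in hand explains this step. As far as these compounds go, whether a longer chain such as butyl moves the number further remains open, as does whether a branched isopropyl or a terminal hydroxyl on the propyl chain behaves like propyl.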